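Ester to free acid on a hydroxylated bicyclic scaffold

The source may hold more compounds than are shown below. What is called first, only, known or untested is meant among the compounds shown, and "the series" means these compounds.

Measured compounds:
compound 1, `C=C(C)[C@H]1CC=C(C)[C@@]2(O)[C@@H]1[C@H](c1ccccc1Br)O[C@@H]2C(=O)OCC1CC1`, in a functional assay on KB3 cells (Homo sapiens) for antiproliferative activity, read by MTT assay, with a stated time of 96 h (a higher number here means a weaker inhibitor, a lower number a stronger inhibitor), gives 50000 nM.
compound 2, `C=C(C)[C@H]1CC=C(C)[C@H]2[C@@H]1[C@H](c1ccccc1Br)O[C@@H]2C(=O)OCC`, in this assay gives > 100000 nM.

Among the compounds with values here, compound 1 is the only compound with an actual number in this assay. The value of compound 2 in this assay is a limit of the assay, not a number, and the limit of > 100000 nM in this assay, at which 1 of the 2 values shown sits, marks where it sits. Within the data shown here, compound 2 also lacks the hydroxy group present on the core of compound 1, so what its two values show is only that compound 1 gives a number while compound 2 does not.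

Compound 3, `C=C(C)[C@H]1CC=C(C)[C@@]2(O)[C@@H]1[C@H](c1ccccc1Br)O[C@@H]2C(=O)O`, is not yet measured in this assay. It differs from compound 1 by hydrogen in place of cyclopropylmethyl on an oxygen next to a carbonyl group, turning the cyclopropylmethoxycarbonyl into a carboxy group. Among the measured compounds shown here, no measured pair shows such a change here, so the expectation rests on compound 1 alone. Since compound 1 is already weak in this assay, the step from compound 1 to compound 3 is expected to be small and toward a weaker inhibitor, roughly a 2.0-fold higher number from compound 1 to compound 3 (0.30 log units; within the scatter), with a real chance that only a limit is reported. Compound 3 is therefore estimated at 100000 nM in this assay, within a range from 40000 nM to 300000 nM.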

Compound 3, half-maximal inhibitory concentration: > 100000 nM
Compound 3 was reported as a limit; the forecaster's own chance of this, stated with the estimate: 55%; the middle value lies on the limit itself.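

Swapping cyclopropylmethyl for hydrogen on an oxygen next to a carbonyl group turns the cyclopropylmethoxycarbonyl into a carboxy group, and in this assay this gives an at least 2.0-fold higher number from compound 1 to compound 3 (0.30 log units; that floor lies within the scatter). The reading for compound 3 is a limit of the assay and not a number, so this step is only a floor: the real gap could be small enough to vanish in the scatter, or much larger. What this adds is a first look at this position, where the cyclopropylmethyl can be removed from compound 1 and the carboxy compound gives no measurable number, leaving compound 1 as the only compound here with an actual value: the limit of > 100000 nM in this assay, at which 2 of the 3 values shown sit.

From the compounds shown here alone, with one measured value and two limits, the size of the effect at this position stays open, and so does whether the cyclopropylmethyl group itself matters or any other group on this oxygen would serve as well. Whether a longer chain on this oxygen, or an amide in place of the carboxy group, would give a number in this assay also remains unanswered.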